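This account rests on a few compounds, and the source may have more. Where it says the series, first, only, none or still open, it means among the compounds named here.

Measured compounds:

Compound 1, `COc1ccc(S(=O)(=O)c2cnc3c(F)cccc3c2-c2cccc(F)c2)cc1`: 3.03 mL/min
Compound 2, `COc1ccc(-c2c(S(=O)(=O)c3cc(F)cc(F)c3)cnc3c(F)cccc23)cc1`: 2.59 mL/min
Compound 3, `COc1ccc(S(=O)(=O)c2cnc3c(F)cccc3c2-c2ccc(Cl)cc2)cc1`: 1.05 mL/min

In an ADME assay on microsomes from liver (Homo sapiens) for metabolic stability, tested at 2.5 uM (a lower number here means slower removal, a higher number faster removal of the compound), compound 3 stands lowest of the three measured compounds, with compound 2 the nearest and compound 1 the furthest, both beyond the scatter. Compound 4, `COc1ccc(-c2c(S(=O)(=O)c3ccc(OC)cc3)cnc3c(F)cccc23)cc1`, has not yet been measured. It differs from compound 3 in one place: methoxy in place of chloro on an aromatic carbon.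

Among the measured compounds shown here, only one measured step concerns the same ring, the change from compound 1 to compound 3, which gave a 2.9-fold lower number from compound 1 to compound 3 (0.46 log units; beyond the scatter). That step swapped one halogen-bearing phenyl for another and so does not speak directly to a methoxy entering in place of chloro. The pair of compound 1 and compound 2 changes a different part of the molecule and offers no guidance here.

For the measured compounds named here, with no step of the same kind on record, the account expects compound 4 to move only modestly, and if at all toward a higher number, by a 1.5-fold higher number from compound 3 to compound 4 (0.18 log units; within the scatter). The value of compound 4 in this assay is therefore estimated at 1.6 mL/min, within 0.7 mL/min to 3.6 mL/min.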

Compound 4, intrinsic clearance in a liver preparation (reported as CLH), per the amount of preparation that the assay uses: 2.12 mL/min
Estimate against measurement, compound 4: 1.3-fold (0.12 log units) below, within the range that was stated.
By their numbers in this assay, from the lowest: compound 3; then compounds 4, 2 and 1 (each within the scatter of the next).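

In this assay methoxy in place of chloro gives a 2.0-fold higher number from compound 3 to compound 4 (0.31 log units; beyond the scatter) and so the low number of compound 3 does not hold for every group on this aromatic carbon. The 4-methoxyphenyl in place of 3-fluorophenyl gives a 1.4-fold lower number from compound 1 to compound 4 (0.16 log units; within the scatter) and so, of the three groups shown on this ring, only 4-chlorophenyl stands apart. On the sulfonyl sulfur, 4-methoxyphenyl in place of 3,5-difluorophenyl gives a 1.2-fold lower number from compound 2 to compound 4 (0.09 log units; within the scatter) and this exchange does not separate the two compounds.

As far as these compounds go, whether an amine, a carboxylic acid or a longer chain on that aromatic carbon would fall with chloro or with methoxy stays open. Nothing at hand bears on what lies behind the step from chloro to methoxy.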